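The compounds below may be only part of what the source reports. "The series", "measured", "known", "first", "only" and "open" are said of these compounds alone.

Working notes on the series. In a functional assay, with a stated time of 30 min, in the absence of a further agent (a higher number here means a weaker inhibitor, a lower number a stronger inhibitor), compound 1 (`Cc1ccc(C(=O)Nc2nnc(-c3ccc(O)c(O)c3)s2)cc1`) gives 34000 nM, compound 2 (`O=C(Nc1nnc(-c2cccc(O)c2O)s1)c1ccccc1`) gives 22300 nM and compound 3 (`CC(=O)Nc1nnc(-c2ccc(O)c(O)c2)s1`) gives 23400 nM. These three values lie within the scatter of one another, so compound 2 holds no distinct place among them.

The next structure is compound 4 (`O=C(Nc1nnc(-c2cccc(O)c2O)s1)C1CCCCC1`), which differs from compound 2 in one place: cyclohexyl in place of phenyl on a carbonyl carbon. In words, this is cyclohexyl in place of phenyl on a carbonyl carbon. Within the data shown here, no measured pair tests this exchange directly.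

Among the measured compounds shown here, the only measured step at such a carbonyl carbon is a 1.5-fold lower number from compound 1 to compound 3 (0.16 log units; within the scatter), with methyl in place of 4-methylphenyl. It bears on the question only indirectly, as the core shared by compound 1 and compound 3 is not the core of compound 2. With that single step as the guide, no change beyond the scatter is expected in this assay for the exchange of phenyl for cyclohexyl, and no direction can be favoured.

The expected size of the change is a 1.1-fold higher number from compound 2 to compound 4 (0.03 log units; within the scatter). Compound 4 is estimated at 24000 nM, with an expected range from 10000 nM to 60000 nM.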

Compound 4, half-maximal inhibitory concentration: 19900 nM
The estimate for compound 4 lay 1.2-fold (0.08 log units) above the measured number, within the range that was stated.
By their numbers in this assay, from the lowest: compounds 4, 2, 3 and 1 (each within the scatter of the next).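

In this assay, among these compounds, the exchange of phenyl for cyclohexyl on a carbonyl carbon gives a 1.1-fold lower number from compound 2 to compound 4 (0.05 log units; within the scatter) and is the first direct reading of this exchange on the core of compound 2. With the carbonyl carbon's amide-type nitrogen kept, the aromatic and the non-aromatic six-membered carbon ring are not told apart by this read-out, and compound 4 at 19900 nM stays within the scatter of compound 2. No measurement is available that would account for this result.

The compounds shown leave open whether a group of another kind at this carbonyl carbon, such as an amine or a carboxylic acid carried on a longer chain, would move the number beyond the scatter on the core of compound 2. Also open, as far as these compounds go, is whether the exchange of phenyl for cyclohexyl would read the same on the core shared by compound 1 and compound 3.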